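Heteroaryl thioethers on the sulfur: outlook for compound 4

The source may report more compounds than this note shows. Statements on the series, on what has been measured and on what is new or still open speak of the compounds shown alone.

Measured so far in an assay on cells (Macrophage) for inhibition of sterol O-acyltransferase 1 (Mus musculus); on this read-out higher numbers stand for weaker inhibition and lower numbers for stronger inhibition:
- compound 1 `CCCCCCN(CCCCCSc1nc2c([nH]1)CCCC2)C(=O)Nc1ccc(F)cc1F` gives 2580 nM
- compound 2 `CCCCCCCN(CCCCCSc1nc(O)c2ccccc2n1)C(=O)Nc1ccc(F)cc1F` gives 11000 nM
- compound 3 `CCCCCCCN(CCCCCSc1ncccn1)C(=O)Nc1ccc(F)cc1F` gives 4370 nM

Compound 3 stands second highest of the three numbers in this assay; its nearest neighbour is compound 1, within the scatter, while compound 2 lies beyond the scatter above it. Within the data shown here, the one single-place step on record is a 2.5-fold lower number from compound 2 to compound 3 (0.40 log units; beyond the scatter), pyrimidin-2-yl in place of 4-hydroxyquinazolin-2-yl on the sulfur, where the six-membered group alone gave the lower number.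

Compound 4 `CCCCCCCN(CCCCCSc1nc(N)c2c[nH]nc2n1)C(=O)Nc1ccc(F)cc1F` goes the other way: a group of 10 heavy atoms (5 carbon, 5 nitrogen; one five-membered aromatic ring with 2 hetero atoms, one six-membered aromatic ring with 2 hetero atoms) in place of a group of 6 heavy atoms (4 carbon, 2 nitrogen; one six-membered aromatic ring with 2 hetero atoms), on a sulfur. Among the measured compounds shown here, the entering group, like the one in compound 2, brings a second ring and hydrogen-bond donors. On the strength of a 2.5-fold lower number from compound 2 to compound 3 (0.40 log units; beyond the scatter) a modest rise in the number is expected for compound 4 in this assay, estimated at 8000 nM (range 3000 nM to 22000 nM). For the measured compounds named here, the expected step of a 1.8-fold higher number from compound 3 to compound 4 (0.26 log units; within the scatter) is of the same order as that single comparison; with only one bearing step, the direction is not secure and a result within the scatter of compound 3 would not surprise.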

Compound 4, half-maximal inhibitory concentration: 72500 nM
Compound 4: middle estimate off by 9.1-fold (0.96 log units), on the low side, and the stated range ends below it.
By their numbers in this assay, from the lowest: compounds 1 and 3 (each within the scatter of the next); then compound 2; then compound 4.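

In this assay, among these compounds, the group on the sulfur can shift the number far more than the earlier comparison showed: the single step on record was a 2.5-fold lower number from compound 2 to compound 3 (0.40 log units; beyond the scatter), whereas this change gives a 17-fold higher number from compound 3 to compound 4 (1.22 log units; beyond the scatter). Two-ring groups on this sulfur are also not interchangeable: replacing 4-hydroxyquinazolin-2-yl gives a 6.6-fold higher number from compound 2 to compound 4 (0.82 log units; beyond the scatter), so the presence of a second ring does not by itself set the number. No available data explain either step.

The compounds shown do not separate the effect of the second ring from that of the hydrogen-bond donors entering with it. Pyrimidin-2-yl carrying only an amine, or a methyl group in place of the hydrogen on the five-membered ring nitrogen, would bear on that question.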